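Removing the methyl from compound 1: an estimate

This account rests on a few compounds, and the source may have more. Where it says the series, first, only, none or still open, it means among the compounds named here.

Measured compounds:
compound 1, `COc1cc(-c2ccnc3cc(-c4ccc(C)cc4)nn23)cc(OC)c1OC`, 48 nM
compound 2, `COc1cc(-c2ccnc3cc(-c4ccc5cc[nH]c5c4)nn23)cc(OC)c1OC`, 187 nM
compound 3, `COc1cc(-c2ccnc3cc(-c4ccc(-c5cnn(C)c5)cc4)nn23)cc(OC)c1OC`, 2110 nM

In a functional assay on HCT-116 cells (Homo sapiens) for inhibition, read by CCK-8 assay, with a stated time of 48 h (a lower number here means a stronger inhibitor, a higher number a weaker inhibitor), compound 1 gives the lowest of the three numbers. Its nearest neighbour is compound 2, reached by the step of a 3.9-fold higher number from compound 1 to compound 2 (0.59 log units; beyond the scatter); compound 3 lies furthest away, reached by the step of a 44-fold higher number from compound 1 to compound 3 (1.64 log units; beyond the scatter). Both measured steps replace or enlarge the group on the outer ring of compound 1, and both weaken inhibition, the larger addition more so.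

Compound 4, `COc1cc(-c2ccnc3cc(-c4ccccc4)nn23)cc(OC)c1OC`, goes the other way: hydrogen in place of methyl on an aromatic carbon. Going by the values given here, no measured step removes a group from this position, so the two steps bear on it only indirectly, by showing that this position is sensitive to what sits there. Since the change here is the loss of a single carbon rather than the addition of a ring, the author expects a step much smaller than either measured one, most likely a slight weakening, possibly none beyond the scatter: a 1.8-fold higher number from compound 1 to compound 4 (0.25 log units; within the scatter). Compound 4 is therefore estimated at 85 nM in this assay, within a range of 30 nM to 250 nM.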

Compound 4, half-maximal inhibitory concentration: 3880 nM
Beside the measured number, compound 4's estimate is 46-fold (1.66 log units) below it; the measured number lies above the stated range.
By their numbers in this assay, from the lowest: compound 1; then compound 2; then compounds 3 and 4 (each within the scatter of the next).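

In this assay, the methyl turns out to matter far more than its single carbon suggests: removing it is a large step (an 81-fold higher number from compound 1 to compound 4 (1.91 log units; beyond the scatter)), larger than either step that replaced or enlarged the group at this place. Having only hydrogen here is no better than carrying the 1-methyl-1H-pyrazol-4-yl group (a 1.8-fold higher number from compound 3 to compound 4 (0.26 log units; within the scatter)), while compound 2 stands well clear of the plain phenyl (a 21-fold higher number from compound 2 to compound 4 (1.32 log units; beyond the scatter)), so among these compounds a smaller group does not simply give stronger inhibition. Nothing available accounts for the size of this loss.

The compounds shown leave open whether the methyl is special or any small group would serve. An ethyl group, a methoxy group or a chlorine atom in its place could settle that.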